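The compounds below may be only part of what the source reports. "The series", "measured", "known", "first", "only" and "open" are said of these compounds alone.

Measured compounds in an ADME assay on HT-29 cells (Homo sapiens) for cytotoxicity, read by MTT assay, with a stated time of 72 h; a lower number here means a stronger inhibitor, a higher number a weaker inhibitor:
compound 1 `C=CC(=O)Nc1cc(Nc2ncc3ncn(-c4ccc(C(C)C)cc4)c3n2)c(OC)cc1N(C)CCN(C)C` gives 15300 nM;
compound 2 `C=CC(=O)Nc1cc(Nc2ncc3ncn(-c4ccc(CC)cc4)c3n2)c(OC)cc1N(C)CCN(C)C` gives 8180 nM;
compound 3 `C=CC(=O)Nc1cc(Nc2ncc3ncn(-c4ccc(F)cc4)c3n2)c(OC)cc1N(C)CCN(C)C` gives 12000 nM.

Compound 2 sits at the low end of these three numbers, yet its steps to the others, a 1.9-fold lower number from compound 1 to compound 2 (0.27 log units; within the scatter) and a 1.5-fold higher number from compound 2 to compound 3 (0.17 log units; within the scatter), both stay within the scatter, so the three are not separable. Compound 4 `C=CC(=O)Nc1cc(Nc2ncc3ncn(-c4ccccc4Cl)c3n2)c(OC)cc1N(C)CCN(C)C` differs from compound 2 by 2-chlorophenyl in place of 4-ethylphenyl on an aromatic nitrogen. Every measured step touches the same group on the aromatic nitrogen: a 1.9-fold lower number from compound 1 to compound 2 (0.27 log units; within the scatter), a 1.3-fold lower number from compound 1 to compound 3 (0.11 log units; within the scatter) and a 1.5-fold higher number from compound 2 to compound 3 (0.17 log units; within the scatter), none beyond the scatter. For the measured compounds named here, no measured compound carries chlorine, and none carries a group where the chlorine of compound 4 sits. The expected step is therefore a 1.2-fold higher number from compound 2 to compound 4 (0.09 log units; within the scatter), nothing beyond the scatter. Compound 4 is estimated at 10000 nM, in the range 4000 nM to 25000 nM.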

Compound 4, half-maximal inhibitory concentration: 11300 nM
Compound 4: the middle estimate sits 1.1-fold (0.05 log units) below what was measured; the measured number falls inside the stated range.
By their numbers in this assay, from the lowest: compounds 2, 4, 3 and 1 (each within the scatter of the next).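

Swapping in 2-chlorophenyl on the aromatic nitrogen gives a 1.4-fold higher number from compound 2 to compound 4 (0.14 log units; within the scatter), a 1.1-fold lower number from compound 3 to compound 4 (0.03 log units; within the scatter) and a 1.4-fold lower number from compound 1 to compound 4 (0.13 log units; within the scatter) in this assay. So a chlorine, and a ring substituent placed differently from those of the earlier compounds, still gives a number that cannot be separated from the others, and all four compounds remain within the scatter of their neighbours. No supporting measurement bears on this result.

The compounds shown leave open whether an amine or a carboxylic acid on this aromatic ring would move the number beyond the scatter. They also leave open whether changes elsewhere on the shared core would do so.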